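Tert-butyl to neopentyl beside a hydroxyl

This account rests on a few compounds, and the source may have more. Where it says the series, first, only, none or still open, it means among the compounds named here.

Of the compounds shown here, three have been measured in a functional assay on a cell-free system (plasma, Homo sapiens), with a stated time of 3 min; a higher number here means a weaker inhibitor, a lower number a stronger inhibitor. Compound 1 `O=C(NCc1cc(Cl)ccc1-n1cnnn1)[C@@H]1CC=NN1C(=O)[C@H](O)c1ccccc1F` gives 1100 nM. Compound 3 `O=C(NCc1cc(Cl)ccc1-n1cnnn1)[C@@H]1CC=NN1C(=O)[C@H](O)c1ccccc1` gives 840 nM. For the measured compounds named here, the only single-point step among them, a 1.3-fold lower number from compound 1 to compound 3 (0.12 log units; within the scatter), stays within the usual scatter. Compound 2 `CC(C)(C)[C@@H](O)C(=O)N1C[C@@H]2C[C@@H]2[C@H]1C(=O)NCc1cc(Cl)ccc1-n1cnnn1` gives 570 nM, the smallest figure of the three, though its gaps to compound 3 and to compound 1 both fall within the scatter, so the three stand level.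

Going by the values given here, compound 4 `CC(C)(C)C[C@@H](O)C(=O)N1C[C@@H]2C[C@@H]2[C@H]1C(=O)NCc1cc(Cl)ccc1-n1cnnn1` is the next compound. neopentyl in place of tert-butyl on a saturated chain carbon bound to a carbonyl carbon and an oxygen on a saturated carbon That change touches the side chain of the hydroxy-acyl group, a part of the molecule no measured step has varied: the one step recorded concerns a fluoro on an aromatic carbon, far from this chain, and even that step stayed within the scatter. Among the compounds with values here, no measured step therefore bears on this change, and no shift beyond the scatter is expected in this assay. Compound 4 is estimated at 600 nM, within 250 nM to 1400 nM, an expected step of a 1.1-fold higher number from compound 2 to compound 4 (0.02 log units; within the scatter).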

Compound 4, half-maximal inhibitory concentration: 910 nM
Beside the measured number, compound 4's estimate is 1.5-fold (0.18 log units) below it; the range from low to high includes it.
By their numbers in this assay, from the lowest: compounds 2, 3, 4 and 1 (each within the scatter of the next).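

This is the only step shown at this position, a saturated chain carbon bound to a carbonyl carbon and an oxygen on a saturated carbon, and in this assay it reads (a 1.6-fold higher number from compound 2 to compound 4 (0.20 log units; within the scatter)). Going from tert-butyl, with 4 heavy atoms, to neopentyl, with 5, therefore leaves compound 2 and compound 4 level, so this position accepts the extra carbon with no shift that can be told apart from the differences seen between repeated measurements. Nothing measured here gives a reason for the size of this step.

The compounds shown leave open whether an amine or a carboxylic acid on this chain, or a chain longer than neopentyl, would give a step beyond the scatter. They also leave open whether the same change would read alike on the core of compound 3.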